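Trading the aromatic ring for a small carbocycle

The compounds below may be only part of what the source reports. "The series", "measured", "known", "first", "only" and "open" are said of these compounds alone.

Three measured compounds share one core and differ only in the group hanging from a saturated chain carbon bound to an aromatic carbon. Compound 1 `COc1cccc(Cc2cnc(CCc3ccc(-c4ccccc4C(=O)O)cc3)[nH]2)c1` carries a 3-methoxyphenyl there, compound 2 `Cc1cccc(Cc2cnc(CCc3ccc(-c4ccccc4C(=O)O)cc3)[nH]2)c1` a 3-methylphenyl and compound 3 `N#Cc1ccc(Cc2cnc(CCc3ccc(-c4ccccc4C(=O)O)cc3)[nH]2)cc1` a 4-cyanophenyl. In an in vitro functional assay on cells for agonist activity at Bombesin receptor subtype-3 (Homo sapiens), read by luminescence and calcium flux (a lower number here means that less compound is needed, a higher number that more compound is needed for the effect), compound 1 gives 4120 nM, compound 2 gives 4310 nM and compound 3 gives 5890 nM. Compound 1 has the lowest of the three numbers, but the steps to the others, a 1.0-fold higher number from compound 1 to compound 2 (0.02 log units; within the scatter) and a 1.4-fold higher number from compound 1 to compound 3 (0.16 log units; within the scatter), both lie within the scatter, so the three cannot be told apart.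

Compound 4 `O=C(O)c1ccccc1-c1ccc(CCc2ncc(CC3CC3)[nH]2)cc1` has not been measured. It differs from compound 1 in that (cyclopropyl in place of 3-methoxyphenyl on a saturated chain carbon bound to an aromatic carbon). The measured steps all swap one six-membered aromatic ring for another; none removes the ring itself, so they bear on this question only loosely. They show that the substituent on that ring hardly matters, which says nothing about doing away with the ring. Replacing the aromatic ring by cyclopropyl is a much larger change, and the expectation is a higher number in this assay, a step of a 2.9-fold higher number from compound 1 to compound 4 (0.46 log units; beyond the scatter) that is expected to go beyond the scatter, though with wide uncertainty. Compound 4 is therefore estimated at 12000 nM, within a range from 3000 nM to 50000 nM.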

Compound 4, half-maximal effective concentration: 1000 nM
Beside the measured number, compound 4's estimate is 12-fold (1.08 log units) above it, outside the stated range (below it).
By their numbers in this assay, from the lowest: compound 4; then compounds 1, 2 and 3 (each within the scatter of the next).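

In this assay, the aromatic ring at this position turns out not to be required: cutting 3-methoxybenzyl down to cyclopropylmethyl, with 8 heavy atoms leaving and 3 entering, gives a 4.1-fold lower number from compound 1 to compound 4 (0.61 log units; beyond the scatter). The same replacement gives a 4.3-fold lower number from compound 2 to compound 4 (0.63 log units; beyond the scatter) and a 5.9-fold lower number from compound 3 to compound 4 (0.77 log units; beyond the scatter), so, unlike the swaps among the aromatic groups, which stayed within the scatter, removing the ring moves the number beyond the scatter against all three aromatic groups shown. Nothing available here explains why the cyclopropyl compound needs less compound for the effect.

With only one non-aromatic group shown, it remains open whether the lower number belongs to the three-membered ring itself or would also appear with a cyclobutyl ring, a cyclohexyl ring, or an open chain such as isopropyl at this place. On these data alone, it is also open how an amine or a hydroxyl group on this small carbon group would shift the number, and whether the cyclopropyl replacement would act the same way on a core other than the one shared here.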